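The source may report more compounds than this note shows. Statements on the series, on what has been measured and on what is new or still open speak of the compounds shown alone.

Working notes on the urea series. Going by the values given here, compound 2 `COc1cc(-c2nn(-c3cccc(NC(=O)Nc4ccc(Cl)c(C(F)(F)F)c4)c3)cc2-c2ccncc2)ccc1Cl` is the only compound here with a numerical value in a functional assay on UO-31 cells (Homo sapiens) for inhibition, read by sulforhodamine B assay, with a stated time of 48 h; on this read-out lower numbers stand for stronger inhibition of growth and higher numbers for weaker inhibition of growth; in this assay compound 2 gives 4100 nM. Compound 1 `O=C(Nc1cccc(-n2cc(-c3ccncc3)c(-c3ccc(Cl)c(O)c3)n2)c1)Nc1ccc(Cl)c(Cl)c1` reaches only the limit of the method, and in this assay compound 1 gives > 32500 nM, a limit rather than a number. Compound 3 `O=C(Nc1cccc(-n2cc(-c3ccncc3)c(-c3ccc(Cl)c(O)c3)n2)c1)Nc1ccc(Cl)c(C(F)(F)F)c1` is the next target in this assay. Its change from compound 2 is hydrogen in place of methyl on an oxygen on an aromatic ring. Among the compounds with values here, no measured pair reports the size of this step. The only bearing on it is the limit of > 32500 nM in this assay, at which 1 of the 2 values shown sits, where compound 1, which carries the same hydroxy, sits at the limit. On that basis a move toward weaker growth inhibition is expected, of the size a 3.7-fold higher number from compound 2 to compound 3 (0.56 log units; beyond the scatter). Compound 3 is estimated at 15000 nM, with a range from 4000 nM to 60000 nM, and a fair chance of a limit only.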

Compound 3, concentration for total growth inhibition: 3010 nM
For compound 3 the middle estimate is 5.0-fold (0.70 log units) above the measured one; the whole stated range lies above it.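

In this assay, methoxy to hydroxy on the 4-chloro-3-methoxyphenyl group gives a 1.4-fold lower number from compound 2 to compound 3 (0.13 log units; within the scatter), so the two groups cannot be told apart here when trifluoromethyl is present. The hydroxy alone therefore does not account for the result of compound 1, whose > 32500 nM is a limit and not a number. Among the hydroxy compounds, trifluoromethyl in place of chloro on an aromatic carbon gives an at least 10-fold lower number from compound 1 to compound 3 (1.03 log units; beyond the scatter), which marks this as the change that separates them.

Going by these compounds, the true size of that step stays open, as it rests on a limit: the limit of > 32500 nM in this assay, at which 1 of the 3 values shown sits. Also open in this assay are whether an ethyl on that oxygen or an amine in place of the hydroxy would keep this level of growth inhibition, and whether the chloro step would read the same alongside methoxy.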